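This account rests on a few compounds, and the source may have more. Where it says the series, first, only, none or still open, it means among the compounds named here.

Measured compounds:
- compound 1 `OC1CCC(Nc2nc(-c3ccccc3)nc3c2nnn3Cc2ccccc2F)CC1`: 1850000 nM
- compound 2 `OCCNc1nc(-c2ccccc2)nc2c1nnn2Cc1ccccc1F`: 54000000 nM
- compound 3 `CCCCCCNc1nc(-c2ccccc2)nc2c1nnn2Cc1ccccc1F`: 25000000 nM

In an assay on isolated protein for binding affinity to adenosine receptor A1 (Bos taurus) (a lower number here means a stronger inhibitor, a higher number a weaker inhibitor), compound 1 gives 1850000 nM, the lowest of the three numbers. Compound 2 gives 54000000 nM, and compound 3 gives 25000000 nM, which puts compound 3 second highest of the three, nearest to compound 2 and furthest from compound 1. The steps measured so far all sit on the nitrogen on the aromatic ring of the shared core: a 29-fold higher number from compound 1 to compound 2 (1.47 log units; beyond the scatter), a 14-fold higher number from compound 1 to compound 3 (1.13 log units; beyond the scatter) and a 2.2-fold lower number from compound 2 to compound 3 (0.33 log units; beyond the scatter).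

Compound 4 `CCCCCCNc1nc(-c2ccccc2)nc2c1nnn2Cc1ccccc1Cl` differs from compound 3 in a different place: chloro in place of fluoro on an aromatic carbon. Among the measured compounds shown here, none of the measured steps touches this halogen, so no measured step bears directly on the change. With only the swap of one halogen atom for another of the same kind, a step within the scatter or a modest one is expected in this assay , in either direction. For compound 4 the estimated value is 20000000 nM, with a range from 6000000 nM to 70000000 nM, corresponding to an expected step of a 1.3-fold lower number from compound 3 to compound 4 (0.10 log units; within the scatter).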

Compound 4, inhibition constant: 31000000 nM
For compound 4 the middle estimate is 1.6-fold (0.19 log units) below the measured one, and the stated range covers the measured number.
By their numbers in this assay, from the lowest: compound 1; then compounds 3, 4 and 2 (each within the scatter of the next, the first and the last beyond it).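

Chloro in place of fluoro on this aromatic carbon, ortho to a large group, gives a 1.2-fold higher number from compound 3 to compound 4 (0.09 log units; within the scatter) in this assay. Among the compounds shown here, with a hexyl chain on the nitrogen, the two halogens therefore cannot be told apart by this measurement, whereas the earlier steps, all made at that nitrogen on the shared core, lie beyond the scatter. Nothing available here bears on the reason for this result.

Among the compounds shown, only fluoro and chloro occupy this place, so it remains open whether a larger or different group there, such as methoxy, trifluoromethyl or an amine, would shift the number. For the compounds shown here, the halogen swap is also seen only with hexyl on the nitrogen, so its outcome with 4-hydroxycyclohexyl, the group on the compound with the lowest number, remains unknown.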